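Taking the 4-chlorophenyl off compound 2

The source may hold more compounds than are shown below. What is called first, only, known or untested is meant among the compounds shown, and "the series" means these compounds.

In a functional assay on A549 cells (Homo sapiens) for antiproliferative activity, read by MTT assay, with a stated time of 48 h (a higher number here means a weaker inhibitor, a lower number a stronger inhibitor), compound 1 (`Cn1cc(C2=C(c3nn(CCn4ccnc4)c4ncccc34)C(=O)N(c3ccccc3)C2=O)c2ccccc21`) gives 43100 nM and compound 2 (`Cn1cc(C2=C(c3nn(CCCN4CCCCC4)c4ncccc34)C(=O)N(c3ccc(Cl)cc3)C2=O)c2ccccc21`) gives 28700 nM within the scatter of each other. Compound 3 (`Cn1cc(C2=C(c3nn(CCCn4ccnc4)c4ncccc34)C(=O)N(c3ccccc3)C2=O)c2ccccc21`) at 1560 nM lies clearly lower than both. Compound 4 (`Cn1cc(C2=C(c3nn(CCCN4CCCCC4)c4ncccc34)C(=O)NC2=O)c2ccccc21`) differs from compound 2 by hydrogen in place of 4-chlorophenyl on an amide-type nitrogen in a ring. Within the data shown here, the one measured step is a 28-fold lower number from compound 1 to compound 3 (1.44 log units; beyond the scatter) on the chain and is large, yet no measured step touches this nitrogen, so the guide is weak. A moderate move to a lower number in this assay is expected, and the estimated step is a 3.2-fold lower number from compound 2 to compound 4 (0.50 log units; beyond the scatter) with wide uncertainty. Compound 4 is estimated at 9000 nM with 1800 nM and 45000 nM as the expected lower and upper ends.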

Compound 4, half-maximal inhibitory concentration: > 100000 nM
Compound 4: only a limit was reported; the forecaster's own chance of this, stated with the estimate: 10%; middle value at least 11-fold (1.04 log units) away from the limit.
By their numbers in this assay, from the lowest: compound 3; then compounds 2 and 1 (each within the scatter of the next). At a limit, above all of these: compound 4.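

In this assay, among these compounds, the first measured step at the amide-type nitrogen shows that this position affects the read-out: hydrogen in place of 4-chlorophenyl gives an at least 3.4-fold higher number from compound 2 to compound 4 (0.54 log units; beyond the scatter). The earlier compounds shown here showed a change only on the chain, whereas this change goes the other way. Compound 4 carries only a limit, so the full size of the step stays unknown: the limit of > 100000 nM in this assay, at which 1 of the 4 values shown sits.

On these data alone, whether the whole aromatic ring or its chlorine matters remains open, as the step removes both together. As far as these compounds go, how a methyl or benzyl group on this nitrogen would read also remains open.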